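Chloro in Place of Methoxy on the Aryl Substituent

The source may hold more compounds than are shown below. What is called first, only, known or untested is meant among the compounds shown, and "the series" means these compounds.

Of the compounds shown here, three sharing one core have been measured in an assay on Sf9 cells for inhibition of protein deacetylase HDAC6 (Homo sapiens), read by fluorescence, with a stated time of 40 min, tested at 100 nM; on this read-out lower numbers stand for less inhibition and higher numbers for more inhibition at the one concentration tested (going by the name of the read-out). Compound 1 `O=C(NO)c1ccc(NCc2nc(-c3ccccc3)nn2-c2cccc(Cl)c2)cc1` gives 62.3%. Compound 2 `CC(C)c1ccc(-n2nc(-c3ccccc3)nc2CNc2ccc(C(=O)NO)cc2)cc1` gives 52.6%. Compound 3 `COc1ccc(-n2nc(-c3ccccc3)nc2CNc2ccc(C(=O)NO)cc2)cc1` gives 63.4%. Among the measured compounds shown here, compound 3 stands highest of the three numbers, but the step of a number 1.1 percentage points higher from compound 1 to compound 3 (within the scatter) lies within the scatter, so compounds 1 and 3 cannot be told apart; only the step of a number 10.8 percentage points higher from compound 2 to compound 3 (beyond the scatter) reaches beyond it.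

Compound 4 `O=C(NO)c1ccc(NCc2nc(-c3ccccc3)nn2-c2ccc(Cl)cc2)cc1` has yet to be measured. It differs from compound 3 in a single place: chloro in place of methoxy on an aromatic carbon. Cut one bond further out, the change reads 4-methoxyphenyl to 4-chlorophenyl, sitting para to a large group.

For the measured compounds named here, two measured steps bear on this. Compound 1 already carries chloro, as 3-chlorophenyl, and the step of a number 1.1 percentage points higher from compound 1 to compound 3 (within the scatter) stayed within the scatter. Going by the values given here, the one step beyond the scatter, a number 10.8 percentage points higher from compound 2 to compound 3 (beyond the scatter), concerned isopropyl rather than chloro, so it says little about the present exchange. Accordingly the step of a number 3.4 percentage points lower from compound 3 to compound 4 (within the scatter) is expected to remain within the scatter. Compound 4 is estimated at 60%, with a range from 48% to 72%.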

Compound 4, a percentage reported as inhibition, at one concentration (the size of the read-out at that concentration, not a potency): 55.4%
Compound 4: the middle estimate sits 4.6 percentage points above what was measured; low and high end bracket the measured number.
By their numbers in this assay, from the lowest: compounds 2, 4, 1 and 3 (each within the scatter of the next, the first and the last beyond it).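

In this assay, among the compounds shown here, chloro in place of methoxy on an aromatic carbon, para to a large group, gives a number 8 percentage points lower from compound 3 to compound 4 (within the scatter) and so offers the first direct reading of chloro at this place, with no separation from methoxy. Chloro in place of isopropyl gives a number 2.8 percentage points higher from compound 2 to compound 4 (within the scatter) and 4-chlorophenyl in place of 3-chlorophenyl gives a number 6.9 percentage points lower from compound 1 to compound 4 (within the scatter) as well, so compound 4 cannot be told apart from any of the other three compounds, and moving the chloro makes no readable difference. Compound 4 thus lies within the scatter of two compounds that are themselves separated by a number 10.8 percentage points higher from compound 2 to compound 3 (beyond the scatter), which means chloro cannot be grouped with either methoxy or isopropyl, and nothing at hand offers a reason for these numbers.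

Going by these compounds, it remains open whether an amine, a carboxylic acid or a longer chain such as butoxy at this same place would move the number beyond the scatter of compound 3. On these data alone, since each compound is read at a single concentration, how these groups rank in potency also stays open.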